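The source may report more compounds than this note shows. Statements on the series, on what has been measured and on what is new or still open speak of the compounds shown alone.

Measured in a functional assay on PC-3 cells (Homo sapiens), read by MTT assay, with a stated time of 48 h; on this read-out lower numbers stand for stronger inhibition and higher numbers for weaker inhibition:
- compound 1 `CCN(CC)CCCNC(=O)c1ccc(C(CC)(CC)c2ccc(OCC(O)C(C)(C)C)c(C)c2)n1CC`: 2500 nM
- compound 2 `C#CCNC(=O)c1ccc(C(CC)(CC)c2ccc(OCC(O)C(C)(C)C)c(C)c2)n1CC`: 16200 nM
- compound 3 `CCn1c(C(=O)NCC(OC)OC)ccc1C(CC)(CC)c1ccc(OCC(O)C(C)(C)C)c(C)c1`: 14600 nM

Compound 3 stands at the high end of these numbers, level with compound 2 within the scatter. Compound 4 `C=CCN(C)C(=O)c1ccc(C(CC)(CC)c2ccc(OCC(O)C(C)(C)C)c(C)c2)n1CC` carries allyl(methyl)amino in place of (2,2-dimethoxyethyl)amino on a carbonyl carbon.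

The closest guide is a 1.1-fold lower number from compound 2 to compound 3 (0.05 log units; within the scatter). The larger steps, a 6.5-fold higher number from compound 1 to compound 2 (0.81 log units; beyond the scatter) and a 5.8-fold higher number from compound 1 to compound 3 (0.77 log units; beyond the scatter), both remove 2-(diethylamino)ethyl, a group absent from compound 4 as well. For the measured compounds named here, no measured step covers loss of the amide hydrogen, so the expectation is uncertain. The estimated change is a 1.1-fold lower number from compound 3 to compound 4 (0.05 log units; within the scatter), with no shift expected beyond the scatter. For compound 4 the expected value in this assay is 13000 nM, with an estimated range from 6000 nM to 30000 nM.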

Compound 4, half-maximal inhibitory concentration: 25900 nM
Compound 4: the middle estimate sits 2.0-fold (0.30 log units) below what was measured; the range from low to high includes it.
By their numbers in this assay, from the lowest: compound 1; then compounds 3, 2 and 4 (each within the scatter of the next).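

In this assay, allyl(methyl)amino on the carbonyl carbon, an entering group with no hydrogen-bond donor, stays level with the earlier side chains, with a 1.8-fold higher number from compound 3 to compound 4 (0.25 log units; within the scatter) and a 1.6-fold higher number from compound 2 to compound 4 (0.20 log units; within the scatter) both read as no real change. The (3-(diethylamino)propyl)amino group of compound 1 remains the only one apart, now with a 10-fold higher number from compound 1 to compound 4 (1.02 log units; beyond the scatter) as the largest step in the series. Nothing measured here bears on the reason for this result.

Open, from the compounds shown here alone, is whether the diethylamino group keeps the number of compound 1 on a shorter two-carbon chain or as a piperidine. Also open, going by these compounds, is whether a carboxylic acid on the carbonyl carbon stays level with compound 4.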